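Removing a Methyl from Compound 1

A few compounds are considered here, and "the series" means these few. Any claim that something is new, unique, unknown or untested is made for them only; others in the source may bear on it.

Compound 1 (`CC(C)=CCC/C(C)=C/CC/C(C)=C/CSc1ccccc1C(=O)N[C@@H](C)C(=O)OC(C)CCOc1no[n+]([O-])c1S(=O)(=O)c1ccccc1`): > 50000 nM
Compound 2 (`CC(C)=CCC/C(C)=C/CC/C(C)=C/CSc1ccccc1C(=O)NCC(=O)OCCCCOc1no[n+]([O-])c1S(=O)(=O)c1ccccc1`): > 50000 nM

In a functional assay on SGC-7901 cells (Homo sapiens) for cytotoxicity, read by MTT assay, with a stated time of 48 h (on this read-out higher numbers stand for weaker inhibition and lower numbers for stronger inhibition), compound 1 gives only a limit (> 50000 nM) and not a number. Compound 2 likewise gives only a limit (> 50000 nM). Both values shown thus sit at the same limit (the limit of > 50000 nM in this assay, at which 2 of the 2 values shown sit), so the standing of compound 1 is known only as a bound.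

Compound 3 (`CC(C)=CCC/C(C)=C/CC/C(C)=C/CSc1ccccc1C(=O)NCC(=O)OC(C)CCOc1no[n+]([O-])c1S(=O)(=O)c1ccccc1`) departs from compound 1 by a single change (hydrogen in place of methyl on a saturated chain carbon bound to an amide-type nitrogen and a carbonyl carbon): hydrogen in place of methyl on a saturated chain carbon bound to an amide-type nitrogen and a carbonyl carbon. Among the compounds with values here, no measured step isolates this change, and no shift beyond the usual scatter is expected in this assay. The expected step is small (a number no higher from compound 1 to compound 3 (the limit leaves the size open)), and a further reading at the limit is likely. Compound 3 is estimated at 50000 nM with an expected range from 20000 nM to 100000 nM in this measurement.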

Compound 3, half-maximal inhibitory concentration: 11900 nM
Compound 3: the middle estimate sits 4.2-fold (0.62 log units) above what was measured, and the stated range ends above it.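

In this assay, hydrogen in place of methyl on a saturated chain carbon bound to an amide-type nitrogen and a carbonyl carbon gives an at least 4.2-fold lower number from compound 1 to compound 3 (0.62 log units; beyond the scatter). Within the data shown here, the earlier compounds offered only limits, so this is the first sign that the position responds to a change: this single replacement separates a compound at the limit from one with a measured number. As far as these compounds go, the full size of the step stays unknown, because compound 1 is known only as a bound: the limit of > 50000 nM in this assay, at which 2 of the 3 values shown sit.

The compounds shown leave open whether a larger group at this carbon, such as an ethyl or an isopropyl, would match the methyl or differ from it. They also leave open how a hydroxymethyl or an amine there would read in this assay.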